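Removing the basic side chain from the aryl oxygen

This account rests on a few compounds, and the source may have more. Where it says the series, first, only, none or still open, it means among the compounds named here.

Measured compounds in an assay on adrenal medulla for inhibition of Vasopressin V2 receptor (Rattus norvegicus), read by radioligand binding; on this read-out lower numbers stand for stronger inhibition and higher numbers for weaker inhibition:
compound 1, `CN1CCN(C(=O)CCCOc2cc(C(=O)N3CCCCc4sccc43)ccc2NC(=O)c2ccccc2-c2ccccc2)CC1`, 1 nM
compound 2, `CN1CCN(CCCCOc2cc(C(=O)N3CCCCc4sccc43)ccc2NC(=O)c2ccccc2-c2ccccc2)CC1`, 7 nM

Compound 2 stands with the higher of the two numbers in this assay. Among the measured compounds shown here, the only measured step is a 7.0-fold higher number from compound 1 to compound 2 (0.85 log units; beyond the scatter), a modest weakening that lies beyond the scatter. Compound 3, `O=C(Nc1ccc(C(=O)N2CCCCc3sccc32)cc1O)c1ccccc1-c1ccccc1`, is not yet measured. It differs from compound 2 in that (hydrogen in place of 4-(4-methylpiperazin-1-yl)butyl on an oxygen on an aromatic ring). For the measured compounds named here, the measured step changes only the group at the far end of that chain, whereas here the whole chain is removed and only a hydroxy remains; no measured pair covers such a removal, so the step bears on it only loosely. Because both measured compounds carry the chain and even changing its end cost a 7.0-fold higher number from compound 1 to compound 2 (0.85 log units; beyond the scatter), removing it is expected to weaken inhibition further, estimated as a 10-fold higher number from compound 2 to compound 3 (1.00 log units; beyond the scatter). Compound 3 is therefore estimated at 70 nM, within 15 nM to 500 nM.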

Compound 3, half-maximal inhibitory concentration: < 10 nM
Compound 3 was reported as a limit; the forecaster's own chance of this, stated with the estimate: 5%; middle value at least 7.0-fold (0.84 log units) away from the limit.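

In this assay, compound 3 is reported only as a limit, so neither its step from compound 1 nor its step from compound 2 can be read: the limit of < 10 nM in this assay, at which 1 of the 3 values shown sits.

The compounds shown leave open whether replacing the 4-(4-methylpiperazin-1-yl)butyl group with hydrogen strengthens or weakens inhibition, or leaves it unchanged.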